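This account rests on a few compounds, and the source may have more. Where it says the series, first, only, none or still open, it means among the compounds named here.

Among the measured compounds shown here, in a functional assay on K562 cells (Homo sapiens) for inhibition, read by trypan blue exclusion, with a stated time of 24 h, tested at 10 uM (on this read-out lower numbers stand for less inhibition of growth and higher numbers for more inhibition of growth at the one concentration tested), compound 1 (`NC(=O)c1cc(Cl)ccc1NC(=O)COc1ccccc1`) gives 87%, the highest of the three numbers measured so far. Compound 2 (`Cc1ccccc1OCC(=O)Nc1ccc(Cl)cc1C(N)=O`) gives 75.9%, and compound 3 (`Cc1ccc(OCC(=O)Nc2ccc(Cl)cc2C(N)=O)cc1`) gives 24.1%. Compound 4 (`Cc1ccc(NC(=O)COc2ccccc2)c(C(N)=O)c1`) has not yet been measured. It differs from compound 1 by a single change, methyl in place of chloro on an aromatic carbon, meta to a carbamoyl group and para to a large group.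

For the measured compounds named here, no measured step makes this swap, so the evidence is indirect. Two steps do put a methyl in place of hydrogen on an aromatic carbon elsewhere in the molecule, and they show a number 11.1 percentage points lower from compound 1 to compound 2 (beyond the scatter) and a number 62.9 percentage points lower from compound 1 to compound 3 (beyond the scatter). Moving that methyl gives a number 51.8 percentage points lower from compound 2 to compound 3 (beyond the scatter), so the size of such a step can differ widely with its place. Both methyl steps went down, so a lower number is expected here, though its size is uncertain. The estimated step is a number 27 percentage points lower from compound 1 to compound 4 (beyond the scatter). For compound 4 the expected value is 60%, with an estimated range of 30% to 88%.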

Compound 4, percent growth inhibition at one concentration: 72%
The estimate for compound 4 lay 12 percentage points below the measured number, and the stated range covers the measured number.
By their numbers in this assay, from the lowest: compound 3; then compounds 4 and 2 (each within the scatter of the next); then compound 1.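

In this assay, the step at this position is a number 15 percentage points lower from compound 1 to compound 4 (beyond the scatter), so the chloro of compound 1 can give way to a methyl with a modest loss, and compound 4 at 72% still keeps most of the inhibition of growth seen with compound 1. Among the compounds shown here, the earlier steps changed only the other end of the molecule, so this is the first sign that the place para to a large group also affects the read-out. Nothing measured here explains why chloro and methyl differ at this place.

With only chloro and methyl shown at this position, it remains open how plain hydrogen, a methoxy group, an amine or a carboxylic acid would read there. As far as these compounds go, it is also open whether this step would keep its size if the phenyl group were changed at the same time.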